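A few compounds are considered here, and "the series" means these few. Any claim that something is new, unique, unknown or untested is made for them only; others in the source may bear on it.

Compound 1 `Cc1cc(NC(=O)Nc2cccc(C(N)=O)c2)c2ccccc2n1` carries a carbamoyl on the phenyl ring of its urea. In an ADME assay on Raji cells (Homo sapiens) for cytotoxicity, with a stated time of 72 h (a lower number here means that less compound is needed, a higher number that more compound is needed for the effect), compound 1 gives only > 25000 nM, a limit of the assay rather than a number. Compound 1 thus sits at the limit of > 25000 nM in this assay, at which 2 of the 3 values shown sit. Compound 2 `Cc1cc(NC(=O)Nc2ccccc2C(N)=O)c2ccccc2n1`, with the carbamoyl moved to another position on the same ring, likewise reaches only a limit in this assay, > 25000 nM. Among the measured compounds shown here, compound 3 `Cc1cc(NC(=O)Nc2ccc(Cl)c(Cl)c2)c2ccccc2n1`, bearing two chlorines instead, is the one member of the set with a number in this assay, at 10000 nM.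

Compound 4 `Cc1cc(NC(=O)Nc2cccc(N(C)C)c2)c2ccccc2n1` has not yet been measured. It differs from compound 1 in one place: dimethylamino in place of carbamoyl on an aromatic carbon. For the measured compounds named here, the shared core and the urea are untouched, so the only change is this exchange of a carbamoyl for a dimethylamino.

Going by the values given here, with no measured step of this kind to lean on, and with compound 1 resting at a limit, the author expects at most a modest move toward the range of compound 3, that is a step of an at least 1.2-fold lower number from compound 1 to compound 4 (0.09 log units; that floor lies within the scatter), and estimates compound 4 at 20000 nM, between 7000 nM and 40000 nM, with a fair chance that the assay again reports only a limit.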

Compound 4, half-maximal effective concentration: > 25000 nM
Compound 4: no number, only a limit; the forecaster's own chance of this, stated with the estimate: 45%; middle value at least 1.2-fold (0.09 log units) from the limit.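

Among the compounds shown here, compound 4, like compound 1, reaches only a limit, so no step between the two can be read: the limit of > 25000 nM in this assay, at which 3 of the 4 values shown sit. The compounds shown leave open whether dimethylamino in place of carbamoyl changes the half-maximal effective concentration in this assay at all.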